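Methoxy added on the aryl ketone ring of compound 2

The source may report more compounds than this note shows. Statements on the series, on what has been measured and on what is new or still open speak of the compounds shown alone.

Three members of the series are measured. Compound 1 `COc1ccc(-c2cc(/C=C/C(=O)c3ccc(N)cc3)[nH]n2)cc1` gives 101% in a functional assay on SK-OV-3 cells (Homo sapiens) for cytotoxicity, read by sulforhodamine B assay, with a stated time of 48 h, tested at 0.01 uM; on this read-out higher numbers stand for a weaker effect at the one concentration tested and lower numbers for a stronger effect; compound 3 `COc1ccc(-c2cc(/C=C/C(=O)c3ccc(N)cc3)[nH]n2)cc1OC` gives 88% in this assay; compound 2 `COc1ccc(C(=O)/C=C/c2cc(-c3cc(OC)c(OC)c(OC)c3)n[nH]2)cc1OC` gives 100% in this assay. Going by the values given here, the one counted step is methoxy in place of hydrogen on an aromatic carbon which moved the read-out by a number 13 percentage points lower from compound 1 to compound 3 (beyond the scatter). The difference between the cores of compound 1 and compound 2 is not broken down here. Compound 4 `COc1cc(C(=O)/C=C/c2cc(-c3cc(OC)c(OC)c(OC)c3)n[nH]2)cc(OC)c1OC` carries the same kind of change relative to compound 2, namely (methoxy in place of hydrogen on an aromatic carbon); around the place it is additionally meta to a methoxy group. The step from compound 2 to compound 4 is estimated at a number 10 percentage points lower from compound 2 to compound 4 (within the scatter), resting on the step from compound 1 to compound 3 of a number 13 percentage points lower from compound 1 to compound 3 (beyond the scatter). Compound 4 is thus expected at 90%, with a range of 75% to 104%.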

Compound 4, a percentage reported as activity, at one concentration (the size of the read-out at that concentration, not a potency): 100%
Compound 4: middle estimate off by 10 percentage points, on the low side; the range from low to high includes it.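

In this assay methoxy in place of hydrogen on an aromatic carbon gives no change at the digits printed from compound 2 to compound 4 (within the scatter) on the core of compound 2. Set beside the step on the core of compound 1, this result does not differ from it: the same change on two cores in this assay, a number 13 percentage points lower (beyond the scatter) from compound 1 to compound 3 and no change at the digits printed (within the scatter) from compound 2 to compound 4, 13 percentage points apart, within the scatter of two such steps

Going by these compounds alone, the two steps are thus compatible with one shared effect of the change, but with only one pair per core and one tested concentration, they do not show that the effect carries from one core to the other.

Still open, going by these compounds, is whether a hydroxy group, a fluorine atom or a longer chain such as ethoxy at this place would move the read-out in this assay on either core. Also open, on these data alone, is how either pair would compare at other concentrations.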